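Amide ring variation in a cathepsin S nitrile series

The compounds below may be only part of what the source reports. "The series", "measured", "known", "first", "only" and "open" are said of these compounds alone.

Measured so far:
compound 1 `N#CC1(NC(=O)[C@@H]2C[C@@H](S(=O)(=O)c3ccccc3)C[C@H]2C(=O)N2CCOCC2)CC1`: 0.7 nM
compound 2 `CC1CCN(C(=O)[C@@H]2C[C@H](S(=O)(=O)c3ccccc3)C[C@H]2C(=O)NC2(C#N)CC2)CC1`: 0.5 nM

In an assay on isolated protein for inhibition of cathepsin S (Homo sapiens), read by fluorescence, with a stated time of 20 min (a higher number here means a weaker inhibitor, a lower number a stronger inhibitor), compound 1 gives 0.7 nM. In this assay compound 2 gives 0.5 nM. Within the data shown here, the only step between them is a 1.4-fold lower number from compound 1 to compound 2 (0.15 log units; within the scatter), a swap of the ring on the carbonyl carbon that leaves the rest of the shared core untouched. Compound 2 thus stands with the lowest of the two numbers, its nearest neighbour being compound 1, and that gap is within the scatter, so no ordering of the two is claimed.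

Compound 3 `CN1CCN(C(=O)[C@@H]2C[C@H](S(=O)(=O)c3ccccc3)C[C@H]2C(=O)NC2(C#N)CC2)CC1` repeats the same kind of change at the same place: 4-methylpiperazin-1-yl in place of 4-methylpiperidin-1-yl on a carbonyl carbon. Among the measured compounds shown here, the one measured step that bears on it, from compound 1 to compound 2, was within the scatter, so a second change of the amide ring on this carbonyl carbon gives no ground to expect movement in this assay beyond the scatter, in either direction. Compound 3 is therefore expected to give about 0.6 nM, within 0.25 nM to 1.6 nM. That amounts to an expected step of a 1.2-fold higher number from compound 2 to compound 3 (0.08 log units; within the scatter).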

Compound 3, half-maximal inhibitory concentration: 2 nM
The estimate for compound 3 lay 3.3-fold (0.52 log units) below the measured number; measured number above the stated range.
By their numbers in this assay, from the lowest: compounds 2 and 1 (each within the scatter of the next); then compound 3.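

In this assay the amide ring on this carbonyl carbon is not a silent position, as the change to 4-methylpiperazin-1-yl from 4-methylpiperidin-1-yl gives a 4.0-fold higher number from compound 2 to compound 3 (0.60 log units; beyond the scatter), although both groups have the same number of heavy atoms and differ in the ring by one carbon exchanged for nitrogen. The change to 4-methylpiperazin-1-yl from morpholin-4-yl gives a 2.9-fold higher number from compound 1 to compound 3 (0.46 log units; beyond the scatter), so among these three compounds the 4-methylpiperazin-1-yl ring stands apart from two rings that remain within the scatter of each other. No supporting evidence is available to explain this separation.

The compounds shown leave open whether the shift follows the second ring nitrogen itself or its methyl group, a question that piperazin-1-yl with a free ring amine or 4-acetylpiperazin-1-yl could address on the same carbonyl carbon. They also leave open whether an open-chain dimethylamino group or a ring without a second hetero atom and without the methyl group, such as piperidin-1-yl, would fall with compounds 1 and 2 or with compound 3.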